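The compounds below may be only part of what the source reports. "The series", "measured", "known", "first", "only" and "open" are said of these compounds alone.

Compound 1, `COc1ccccc1Oc1ccc2c(NCCCNCc3ccco3)ccnc2c1`, gives 9.28 in a physicochemical assay for acid dissociation.
Compound 2, `CC(C)Cc1ccc2c(NCCCNCc3ccco3)ccnc2c1`, gives 9.47.
Compound 3, `Fc1ccc(Oc2ccc3c(NCCCNCc4ccco4)ccnc3c2)cc1`, gives 9.28.

Compound 3 stands level with compound 1 at the digits shown, and the step from the second-highest number is a number 0.19 log units lower from compound 2 to compound 3 (within the scatter). Compound 4, `COc1ccc(Oc2ccc3c(NCCCNCc4ccco4)ccnc3c2)cc1`, differs from compound 3 by methoxy in place of fluoro on an aromatic carbon. The measured step that bears on this sits on the same ring: no change at the digits printed from compound 1 to compound 3 (within the scatter). The other change, a number 0.19 log units higher from compound 1 to compound 2 (within the scatter), likewise stays within the scatter. For the measured compounds named here, since no step in this set reached beyond the scatter, no step beyond the scatter is expected in this assay for compound 4. Compound 4 is therefore expected to give 9.3, within a range of 9.05 to 9.55. The estimated step is a number 0.02 log units higher from compound 3 to compound 4 (within the scatter).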

Compound 4, acid dissociation constant: 9.28
Beside the measured number, compound 4's estimate is 0.02 log units above it; low and high end bracket the measured number.
By their numbers in this assay, from the lowest: compounds 1, 3, 4 and 2 (each within the scatter of the next).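

In this assay, methoxy in place of fluoro on the aromatic carbon para to a large group gives no change at the digits printed from compound 3 to compound 4 (within the scatter), so this position now holds two different groups with no step beyond the scatter. The 4-methoxyphenyl in place of 2-methoxyphenyl on the oxygen gives no change at the digits printed from compound 1 to compound 4 (within the scatter), and 4-methoxyphenoxy in place of isobutyl gives a number 0.19 log units lower from compound 2 to compound 4 (within the scatter). All three new steps stay within the scatter.

No evidence is available to account for these readings. Going by these compounds, whether an amine or a carboxylic acid at this place would give a step beyond the scatter stays open.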